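From compound 3 to compound 4: the methyl moves

The source may hold more compounds than are shown below. What is called first, only, known or untested is meant among the compounds shown, and "the series" means these compounds.

Measured in a functional assay on MCF cells (Homo sapiens) for antiproliferative activity, with a stated time of 72 h; on this read-out higher numbers stand for weaker inhibition and lower numbers for stronger inhibition:
compound 1 `COc1cccc(CNc2ncnc3c2ncn3[C@@H]2O[C@H](CO)[C@@H](O)[C@H]2O)c1OC`: > 166000 nM (a limit)
compound 2 `OC[C@H]1O[C@@H](n2cnc3c(NCc4c(F)ccc(F)c4F)ncnc32)[C@H](O)[C@@H]1O`: > 166000 nM (a limit)
compound 3 `Cc1cccc(CNc2ncnc3c2ncn3[C@@H]2O[C@H](CO)[C@@H](O)[C@H]2O)c1O`: 6900 nM

Compound 3 , at 6900 nM, is the only one of the three with a number rather than a limit. The other two results mark (the limit of > 166000 nM in this assay, at which 2 of the 3 values shown sit).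

The next structure is compound 4 `Cc1ccc(O)c(CNc2ncnc3c2ncn3[C@@H]2O[C@H](CO)[C@@H](O)[C@H]2O)c1`, and the change is 2-hydroxy-5-methylphenyl in place of 2-hydroxy-3-methylphenyl on a saturated chain carbon bound to a nitrogen on an aromatic ring. The two groups differ only in where the methyl sits.

Two measured steps lead to compound 3 : an at least 24-fold lower number from compound 1 to compound 3 (1.38 log units; beyond the scatter) and an at least 24-fold lower number from compound 2 to compound 3 (1.38 log units; beyond the scatter). Both are large, but each replaces the whole group and neither isolates a move of the methyl. The third, a step that the two limits leave unreadable from compound 1 to compound 2, adds nothing on size.

In this assay, no change beyond the scatter is the most likely outcome, with either direction possible and a larger rise a real risk. The expected step is a 1.2-fold higher number from compound 3 to compound 4 (0.06 log units; within the scatter). For compound 4 the estimated value is 8000 nM, with an expected range from 2500 nM to 50000 nM.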

Compound 4, half-maximal inhibitory concentration: > 166000 nM
Compound 4: no number, only a limit (the forecaster's own chance of this, stated with the estimate: 15%); middle value at least 20-fold (1.31 log units) from the limit.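

In this assay, within the data shown here, the earlier steps each replaced the whole group, whereas here the atoms stay the same and moving the methyl alone gives an at least 24-fold higher number from compound 3 to compound 4 (1.38 log units; beyond the scatter). The 2-hydroxy-3-methylphenyl and 2-hydroxy-5-methylphenyl groups are therefore not interchangeable on this saturated chain carbon, and of the compounds shown only compound 3 gives a number. The result for compound 4 is a limit, not a number, and the steps among compounds 1, 2 and 4 cannot be read: the limit of > 166000 nM in this assay, at which 3 of the 4 values shown sit.

Going by these compounds, it remains open whether an ethyl group or a chlorine in place of the methyl of 2-hydroxy-3-methylphenyl would keep a measurable value. Also open is whether the hydroxy group is needed at all, as no compound shown pairs the 3-methyl group with a hydrogen or a methoxy group in its place.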